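The source may report more compounds than this note shows. Statements on the series, on what has been measured and on what is new or still open speak of the compounds shown alone.

Of the compounds shown here, three sharing one core have been measured in an ADME assay on Vero cells (Chlorocebus sabaeus) for cytotoxicity, read by MTT assay; on this read-out higher numbers stand for weaker inhibition and lower numbers for stronger inhibition. Compound 1 `C=CCOc1cc(OC)c(C(=O)/C=C/c2ccc(F)cc2)c(OCC=C)c1` gives 13600 nM there. Compound 2 `C=CCOc1cc(OC)c(C(=O)/C=C/c2ccco2)c(OCC=C)c1` gives 191000 nM, and compound 3 `C=CCOc1cc(OC)c(C(=O)/C=C/c2ccc(C)cc2)c(OCC=C)c1` gives 211000 nM. Compound 2 thus holds the second highest of the three numbers: its nearest neighbour is compound 3, from which it is separated by a 1.1-fold higher number from compound 2 to compound 3 (0.04 log units; within the scatter), and its furthest is compound 1, from which it is separated by a 14-fold higher number from compound 1 to compound 2 (1.15 log units; beyond the scatter).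

The unmeasured compound 4 `C=CCOc1cc(OC)c(C(=O)/C=C/c2ccc([N+](=O)[O-])cc2)c(OCC=C)c1` differs from compound 2 in one place: 4-nitrophenyl in place of furan-2-yl on a double-bonded chain carbon bound to a double-bonded chain carbon. Within the data shown here, two measured steps bear on this exchange; each of them also swaps the furan-2-yl against a six-membered aromatic ring of carbon only, either 4-fluorophenyl or 4-methylphenyl. The step of a 14-fold higher number from compound 1 to compound 2 (1.15 log units; beyond the scatter) ran in the opposite direction and was large, so read backwards it points to a much lower number when 4-fluorophenyl takes the place of furan-2-yl. The step of a 1.1-fold higher number from compound 2 to compound 3 (0.04 log units; within the scatter) shows no change beyond the scatter when 4-methylphenyl does so. The nitro group is neither of these, and nothing measured here tells how it will behave. Weighing both precedents, a moderate drop in the number is expected, a 3.2-fold lower number from compound 2 to compound 4 (0.50 log units; beyond the scatter), with wide uncertainty. Compound 4 is therefore estimated at 60000 nM, in a range from 12000 nM to 220000 nM.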

Compound 4, half-maximal inhibitory concentration: 12600 nM
Beside the measured number, compound 4's estimate is 4.8-fold (0.68 log units) above it; the measured number falls inside the stated range.
By their numbers in this assay, from the lowest: compounds 4 and 1 (each within the scatter of the next); then compounds 2 and 3 (each within the scatter of the next).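

In this assay, 4-nitrophenyl in place of furan-2-yl gives a 15-fold lower number from compound 2 to compound 4 (1.18 log units; beyond the scatter), so a large step towards the lower numbers at this place on the double-bonded chain carbon is no longer seen with 4-fluorophenyl alone. Among these compounds, on the aromatic carbon, nitro in place of methyl gives a 17-fold lower number from compound 3 to compound 4 (1.22 log units; beyond the scatter), whereas nitro in place of fluoro gives only a 1.1-fold lower number from compound 1 to compound 4 (0.03 log units; within the scatter); the four compounds thus split into two groups, with compounds 1 and 4 at the low numbers and compounds 2 and 3 at the high numbers, and compound 3 is the one compound with a substituted phenyl ring that goes against any reading of a substituted phenyl ring as enough for the low numbers. Nothing available here accounts for this split between fluoro and nitro on one side and methyl on the other.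

On these data alone, it remains open on which side an amine, a nitrile, a chloro group or a carboxylic acid on the same aromatic carbon would fall in this assay. As far as these compounds go, it is also open whether an unsubstituted phenyl ring would stay with compounds 2 and 3 or join compounds 1 and 4.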